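The source may report more compounds than this note shows. Statements on the series, on what has been measured and on what is new or still open speak of the compounds shown alone.

Measured in a functional assay on K562 cells (Homo sapiens) for inhibition, read by MTT assay, with a stated time of 72 h; a lower number here means a stronger inhibitor, a higher number a weaker inhibitor:
- compound 1 `O=[N+]([O-])c1cccc(-c2csc(N/N=C/c3ccc(C(F)(F)F)cc3)n2)c1`: 10200 nM
- compound 2 `COc1ccc(-c2csc(N/N=C/c3ccc(C(F)(F)F)cc3)n2)cc1`: > 66100 nM

Compound 2 stands at > 66100 nM, which is a limit of the assay and not a number. Compound 3 `FC(F)(F)c1ccc(/C=N/Nc2nc(-c3ccc(Cl)c(Cl)c3)cs2)cc1` has 3,4-dichlorophenyl in place of 4-methoxyphenyl on an aromatic carbon. Within the data shown here, the one measured step at this place is an at least 6.4-fold higher number from compound 1 to compound 2 (0.81 log units; beyond the scatter), and it came with 4-methoxyphenyl in place of 3-nitrophenyl. Compound 3 loses that 4-methoxyphenyl, so a number nearer to compound 1 at 10200 nM is expected. The expected change in this assay is of similar size, towards a lower number: an at least 3.3-fold lower number from compound 2 to compound 3 (0.51 log units; beyond the scatter). For compound 3 the estimate is 20000 nM, with an expected range of 7000 nM to 60000 nM.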

Compound 3, half-maximal inhibitory concentration: > 60000 nM
Compound 3: no number, only a limit; the forecaster's own chance of this, stated with the estimate: 25%; middle value at least 3.0-fold (0.47 log units) away from the limit.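

In this assay compound 3 stands at > 60000 nM, a limit of the assay and not a number. 3,4-Dichlorophenyl in place of 3-nitrophenyl gives an at least 5.8-fold higher number from compound 1 to compound 3 (0.76 log units; beyond the scatter), so a higher number now follows the loss of 3-nitrophenyl with a second group, not with 4-methoxyphenyl alone. The step between compound 2 and compound 3 cannot be read, as both values are limits.

Still open, as far as these compounds go, is whether the nitro group itself or its place on the phenyl ring carries the lower number of compound 1. A 4-nitrophenyl, or a phenyl bearing a nitrile or a carboxylic acid at that place, would separate the two.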